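A Methyl-Bearing Analogue Expected to Stay Near the Limit

This account rests on a few compounds, and the source may have more. Where it says the series, first, only, none or still open, it means among the compounds named here.

Measured compounds in a functional assay on U-937 cells (Homo sapiens) for cytotoxicity, read by MTT assay, with a stated time of 48 h; a higher number here means a weaker inhibitor, a lower number a stronger inhibitor:
compound 1, `Fc1cccc(-c2nc(Nc3ccccc3F)c3cc(F)ccc3n2)c1`, gives > 50000 nM, which is a limit of the assay and not a number.
compound 2, `Oc1ccccc1Nc1nc(-c2cccc(F)c2)nc2ccc(F)cc12`, gives 46300 nM.
compound 3, `Nc1cccc(Nc2nc(-c3cccc(F)c3)nc3ccc(F)cc23)c1`, gives > 50000 nM, again a limit of the assay.

Compound 1 therefore stands at the limit rather than at a measured number; this is the limit of > 50000 nM in this assay, at which 2 of the 3 values shown sit. Compound 4, `Cc1cccc(Nc2nc(-c3cccc(F)c3)nc3ccc(F)cc23)c1`, differs from compound 1 in one place: 3-methylphenyl in place of 2-fluorophenyl on a nitrogen on an aromatic ring. Two measured steps change the same nitrogen. The step that the two limits leave unreadable from compound 1 to compound 3 starts and ends at the limit, so its size cannot be read. The step of an at least 1.0-fold higher number from compound 2 to compound 3 (0.03 log units; that floor lies within the scatter) lies within the scatter. The remaining step, an at least 1.0-fold lower number from compound 1 to compound 2 (0.03 log units; that floor lies within the scatter), alters a different ring and is also within the scatter. Every measured compound sits at or close to the limit, and no change tried so far has moved the read-out beyond the scatter. For compound 4 a step that the limit leaves unreadable from compound 1 to compound 4 is therefore expected, which amounts to no shift beyond the scatter. Compound 4 is estimated at 55000 nM, within 20000 nM to 150000 nM, and will most likely be reported once more only as a limit.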

Compound 4, half-maximal inhibitory concentration: > 50000 nM
Compound 4 gave a limit, no number (the forecaster's own chance of this, stated with the estimate: 70%); the middle value lies beyond the limit too.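

In this assay compound 4 gives > 50000 nM, which is a limit of the assay and not a number. This shows that 3-methylphenyl on the nitrogen, a ring of carbon only, also fails to bring a readable value, as 2-fluorophenyl and 3-aminophenyl did in the same place. The steps to compound 4 from compound 1 and from compound 3 cannot be read, and the one step that can be read is an at least 1.0-fold higher number from compound 2 to compound 4 (0.03 log units; that floor lies within the scatter), so this change shows no shift beyond the scatter, and the limit now covers most of the set: the limit of > 50000 nM in this assay, at which 3 of the 4 values shown sit.

On these data alone, how far compound 1, compound 3 and compound 4 lie past that limit stays unknown, so they cannot be put in any order among themselves. As far as these compounds go, it also remains open whether a quite different group on this ring, such as a carboxylic acid or an amine carried on a longer chain, would bring the read-out to a clearly lower number.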